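Branching the indole nitrogen substituent toward a bulkier alkyl group

This account rests on a few compounds, and the source may have more. Where it says the series, first, only, none or still open, it means among the compounds named here.

Three compounds sharing one core differ only in the group on an aromatic nitrogen. Compound 1 `CC(C)=CCn1ccc2cc(/C(C)=C/C(=O)Nc3ccccc3OCCCC(=O)O)ccc21` gives 120 nM in an assay on Prostate gland for inhibition of steroid 5-alpha-reductase (Rattus norvegicus); a higher number here means a weaker inhibitor, a lower number a stronger inhibitor. Compound 2 `CCC(C)n1ccc2cc(/C(C)=C/C(=O)Nc3ccccc3OCCCC(=O)O)ccc21` gives 67 nM, and compound 3 `CCCC(C)n1ccc2cc(/C(C)=C/C(=O)Nc3ccccc3OCCCC(=O)O)ccc21` gives 7.8 nM. The step of a 1.8-fold lower number from compound 1 to compound 2 (0.25 log units; within the scatter) is small, whereas an 8.6-fold lower number from compound 2 to compound 3 (0.93 log units; beyond the scatter) and a 15-fold lower number from compound 1 to compound 3 (1.19 log units; beyond the scatter) are clear gains, so compound 3 stands lowest of the three, beyond the scatter from both others.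

Compound 4 `C/C(=C\C(=O)Nc1ccccc1OCCCC(=O)O)c1ccc2c(ccn2C(C(C)C)C(C)C)c1` carries the change (1-isopropyl-2-methylpropyl in place of 1-methylbutyl on an aromatic nitrogen). For the measured compounds named here, the steps that bear on it are an 8.6-fold lower number from compound 2 to compound 3 (0.93 log units; beyond the scatter) and a 15-fold lower number from compound 1 to compound 3 (1.19 log units; beyond the scatter), both showing that a larger, more branched alkyl group lowered the number. Going by the values given here, compound 4 adds still more branching, yet with only three compounds no firm pattern can be claimed, and gains of that size may not repeat. Compound 4 is therefore expected to give about 6 nM, within a range from 2 nM to 25 nM. The expected step is a 1.3-fold lower number from compound 3 to compound 4 (0.11 log units; within the scatter), that is, a number near compound 3 or somewhat lower.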

Compound 4, half-maximal inhibitory concentration: 14 nM
Estimate against measurement, compound 4: 2.3-fold (0.37 log units) below; low and high end bracket the measured number.
By their numbers in this assay, from the lowest: compounds 3 and 4 (each within the scatter of the next); then compounds 2 and 1 (each within the scatter of the next).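

In this assay, the 1-isopropyl-2-methylpropyl group on the aromatic nitrogen keeps most of the gain over the smaller or unsaturated groups, with a 4.8-fold lower number from compound 2 to compound 4 (0.68 log units; beyond the scatter) and an 8.6-fold lower number from compound 1 to compound 4 (0.93 log units; beyond the scatter) both beyond the scatter. Replacing 1-methylbutyl (5 heavy atoms) with this group (7 heavy atoms) gives a 1.8-fold higher number from compound 3 to compound 4 (0.25 log units; within the scatter), so compounds 3 and 4 cannot be told apart, and compound 4 goes against any simple rule that more branched alkyl bulk keeps lowering the number. Nothing available explains these differences in terms of how the groups act.

Still open, on these data alone, is how a ring on this nitrogen, such as cyclohexyl or phenyl, would compare with these open-chain groups. A longer chain, or one ending in an amine or a carboxylic acid, also remains untested among the compounds shown here.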